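Iodo to nitro on the shared core

The compounds below may be only part of what the source reports. "The series", "measured", "known", "first", "only" and "open" are said of these compounds alone.

For the measured compounds named here, in a functional assay on COLO 205 cells (Homo sapiens) for inhibition, read by sulforhodamine B assay, with a stated time of 48 h, tested at 50 uM (on this read-out lower numbers stand for less inhibition of growth and higher numbers for more inhibition of growth at the one concentration tested), compound 2 (`O=C1C(=O)N(CCCCCn2cc(COc3cc(=O)oc4ccccc34)nn2)c2ccc(I)cc21`) gives 30% as the lowest of the two numbers so far, with compound 1 (`O=C1C(=O)N(CCCCCn2cc(COc3cc(=O)oc4ccccc34)nn2)c2ccc(Cl)cc21`) at 48% as the only other value. Compound 3 (`O=C1C(=O)N(CCCCCn2cc(COc3cc(=O)oc4ccccc34)nn2)c2ccc([N+](=O)[O-])cc21`) has nitro in place of iodo on an aromatic carbon and remains unmeasured. Going by the values given here, the only measured step bearing on it is a number 18 percentage points lower from compound 1 to compound 2 (beyond the scatter) for iodo in place of chloro, modest and beyond the scatter. Nitro itself is untested, so a modest upward move of similar size is expected. The expected change is a number 12 percentage points higher from compound 2 to compound 3 (beyond the scatter) in this assay on this single precedent. The estimate for compound 3 is 42% with an expected range from 24% to 60% in this read-out.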

Compound 3, percent growth inhibition at one concentration: 23%
Compound 3: middle estimate off by 19 percentage points, on the high side, outside the stated range (below it).
By their numbers in this assay, from the lowest: compounds 3 and 2 (each within the scatter of the next); then compound 1.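

In this assay nitro in place of iodo on this aromatic carbon gives a number 7 percentage points lower from compound 2 to compound 3 (within the scatter) and so does not separate the two groups. Nitro in place of chloro gives a number 25 percentage points lower from compound 1 to compound 3 (beyond the scatter) and leaves chloro as the one group of the three that stands apart, with iodo and nitro together on the lower side. Nothing on hand explains this result.

Going by these compounds, how an amine or a carboxylic acid on this aromatic carbon would read against chloro stays open. On these data alone, whether the same order holds with a longer chain on the shared core also stays open.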